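This account rests on a few compounds, and the source may have more. Where it says the series, first, only, none or still open, it means among the compounds named here.

For the measured compounds named here, compound 3, `Brc1ccc(-c2cn3ccnc3c(-c3ccc4ncn(C5CCCCC5)c4c3)n2)cc1`, gives 35.5% in a functional assay on NCI-H522 cells (Homo sapiens) for inhibition, read by sulforhodamine B assay, with a stated time of 48 h, tested at 10 uM (a lower number here means less inhibition, a higher number more inhibition at the concentration tested (going by the name of the read-out)), the highest of the three numbers measured so far. Compound 1, `Brc1cn2ccnc2c(-c2ccc3ncn(C4CCCCC4)c3c2)n1`, gives 16.2% in this assay, and compound 2, `c1cn2cc(-c3ccsc3)nc(-c3ccc4ncn(C5CCCCC5)c4c3)c2n1`, gives 10.3%. The steps reached compound 3 from both: a number 19.3 percentage points higher from compound 1 to compound 3 (beyond the scatter), and a number 25.2 percentage points higher from compound 2 to compound 3 (beyond the scatter), while a number 5.9 percentage points lower from compound 1 to compound 2 (within the scatter).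

The next compound, compound 4, `COc1ccccc1-c1cn2ccnc2c(-c2ccc3ncn(C4CCCCC4)c3c2)n1`, differs from compound 3 in one place: 2-methoxyphenyl in place of 4-bromophenyl on an aromatic carbon. Going by the values given here, none of the measured steps exchanges one six-membered carbon ring for another; the two steps that bear on it only show that a six-membered carbon ring at this position, in compound 3, gave more inhibition than bromo in compound 1 or thiophen-3-yl in compound 2. Whether the 2-methoxyphenyl keeps that number is not told by these data, so a step within the scatter or a modest fall is expected, with a number 7.5 percentage points lower from compound 3 to compound 4 (within the scatter) as the estimated change. For compound 4 the expected value in this assay is 28%, in the range 10% to 46%.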

Compound 4, a percentage reported as inhibition, at one concentration (the size of the read-out at that concentration, not a potency): 22.2%
Compound 4: the middle estimate sits 5.8 percentage points above what was measured; measured number inside the range.
By their numbers in this assay, from the lowest: compounds 2, 1 and 4 (each within the scatter of the next, the first and the last beyond it); then compound 3.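

In this assay, exchanging one six-membered carbon ring for another at this position is not neutral (a number 13.3 percentage points lower from compound 3 to compound 4 (beyond the scatter)), so the number depends on what the ring carries or where it carries it, not on the ring alone. The 2-methoxyphenyl group still gives more inhibition than thiophen-3-yl (a number 11.9 percentage points higher from compound 2 to compound 4 (beyond the scatter)), but it does not separate from bromo (a number 6 percentage points higher from compound 1 to compound 4 (within the scatter)), so a six-membered carbon ring here does not by itself raise the number above that of bromo. Nothing given here accounts for these differences.

The compounds shown leave open whether the substituent itself or its place on the ring matters, since 4-bromophenyl and 2-methoxyphenyl differ in both. From the compounds shown here alone, how a phenyl ring carrying an amine or a carboxylic acid would behave at this position also remains open.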